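Methyl for Bromo on the Benzamide Ring of Compound 3

The source may hold more compounds than are shown below. What is called first, only, known or untested is meant among the compounds shown, and "the series" means these compounds.

Compound 1, `NC(=O)c1c(NC(=O)c2ccccc2Br)sc2c1CCN(C(=S)Nc1ccccc1F)C2`, gives in a functional assay on MKN-74 cells (Homo sapiens) for antiproliferative activity, with a stated time of 24 h (a higher number here means a weaker inhibitor, a lower number a stronger inhibitor), a value of > 50000 nM, which is a limit of the assay.
Compound 2, `NC(=O)c1c(NC(=O)c2ccccc2Br)sc2c1CCN(C(=S)Nc1ccccc1Br)C2`, gives in this assay a value of 13700 nM.
Compound 3, `NC(=O)c1c(NC(=O)c2ccccc2Br)sc2c1CCN(C(=S)Nc1ccccc1C(F)(F)F)C2`, gives in this assay a value of 24300 nM.

Compound 3 has one of the two numbers measured outright; the step of a 1.8-fold higher number from compound 2 to compound 3 (0.25 log units; within the scatter) lies within the scatter, so it does not stand apart from its nearest neighbour. Compound 1 gave only a limit (the limit of > 50000 nM in this assay, at which 1 of the 3 values shown sits). The measured steps of an at least 3.6-fold lower number from compound 1 to compound 2 (0.56 log units; beyond the scatter) and an at least 2.0-fold lower number from compound 1 to compound 3 (0.31 log units; beyond the scatter) both concern the ring bound to the thiourea and are at least modest.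

Compound 4, `Cc1ccccc1C(=O)Nc1sc2c(c1C(N)=O)CCN(C(=S)Nc1ccccc1C(F)(F)F)C2`, differs from compound 3 on the other aromatic ring: methyl in place of bromo on an aromatic carbon. Going by the values given here, none of the measured steps touches this position, so they give no direct guide; they show only how far the values spread in this assay. Compound 4 is therefore expected to show no step beyond the scatter, a 1.0-fold lower number from compound 3 to compound 4 (0.01 log units; within the scatter). The estimate for compound 4 is 24000 nM, with a range from 8000 nM to 70000 nM.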

Compound 4, half-maximal inhibitory concentration: 17400 nM
Beside the measured number, compound 4's estimate is 1.4-fold (0.14 log units) above it, within the range that was stated.
By their numbers in this assay, from the lowest: compounds 2, 4 and 3 (each within the scatter of the next). At a limit, above all of these: compound 1.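

In this assay, replacing 2-bromophenyl with 2-methylphenyl, ortho to a large group, gives a 1.4-fold lower number from compound 3 to compound 4 (0.15 log units; within the scatter), so bromo and methyl cannot be told apart at this position. Going by these compounds alone, the steps that went beyond the scatter earlier all started from compound 1 and concerned the ring bound to the thiourea, whereas this is the first reading of the other aromatic ring, and it shows no such step for this exchange. Nothing shown here bears on why these two groups read alike.

On these data alone, with only bromo and methyl at this position, it remains open whether an amine, a carboxylic acid or a longer chain there would move the value beyond the scatter. As far as these compounds go, it also remains open whether methyl and bromo would read alike with bromo on the thiourea ring, as in compound 2.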